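Ester chain variation in a dihydropyridine calcium channel series

The source may hold more compounds than are shown below. What is called first, only, known or untested is meant among the compounds shown, and "the series" means these compounds.

Three esters of a shared core have been measured in an assay on isolated protein (strain albino) for antagonist activity at Voltage-dependent L-type calcium channel subunit alpha-1C (Cavia porcellus); a higher number here means a weaker inhibitor, a lower number a stronger inhibitor. Compound 1 `CCOC(=O)C1=C(C)NC(C)=C(C(=O)OC)C1c1cnc(SC)n1Nc1ccccc1` gives 1.66 nM, compound 2 `CCCOC(=O)C1=C(C)NC(C)=C(C(=O)OC)C1c1cnc(SC)n1Nc1ccccc1` gives 2.4 nM, and compound 3 `COCCOC(=O)C1=C(C)NC(C)=C(C(=O)OC)C1c1cnc(SC)n1Nc1ccccc1` gives 9.65 nM, the highest number of the three. The steps of a 5.8-fold higher number from compound 1 to compound 3 (0.76 log units; beyond the scatter) and a 4.0-fold higher number from compound 2 to compound 3 (0.60 log units; beyond the scatter) show that the methoxy weakens inhibition, whereas a 1.4-fold higher number from compound 1 to compound 2 (0.16 log units; within the scatter) shows that a methyl changes little. Compound 4 `COC(=O)C1=C(C)NC(C)=C(C(=O)OCCCc2ccccc2)C1c1cnc(SC)n1Nc1ccccc1` differs from compound 3 by benzyl in place of methoxy on a saturated chain carbon, two bonds along the chain from an oxygen next to a carbonyl group. Since the methoxy is removed in favour of a carbon-only group, a recovery toward the numbers of compounds 1 and 2 is expected. For compound 4 the estimate in this assay is 3 nM, within 1 nM to 10 nM. This estimate corresponds to an expected step of a 3.2-fold lower number from compound 3 to compound 4 (0.51 log units; beyond the scatter).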

Compound 4, half-maximal inhibitory concentration: 3.05 nM
Compound 4: the middle estimate sits 1.0-fold (0.01 log units) below what was measured; the measured number falls inside the stated range.
By their numbers in this assay, from the lowest: compounds 1, 2 and 4 (each within the scatter of the next); then compound 3.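

In this assay the step of a 3.2-fold lower number from compound 3 to compound 4 (0.50 log units; beyond the scatter) shows that this position accepts a far bigger, ring-bearing 3-phenylpropyl chain, with no separation from the small esters: a 1.3-fold higher number from compound 2 to compound 4 (0.10 log units; within the scatter) and a 1.8-fold higher number from compound 1 to compound 4 (0.26 log units; within the scatter) both stay within the scatter. Among these four esters only the 2-methoxyethyl chain of compound 3 stands apart, so chain size alone does not set the number here. No measurement available explains what sets the methoxy apart.

On these data alone, whether a 3-methoxypropyl chain or a terminal amine would behave like the methoxy or like the benzyl remains open.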